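Shortening the sulfonyl chain in the salicylanilide series

The source may report more compounds than this note shows. Statements on the series, on what has been measured and on what is new or still open speak of the compounds shown alone.

Of the compounds shown here, two have been measured in a physicochemical assay for lipophilicity; a lower number here means a more polar compound, a higher number a more lipophilic compound. Compound 1 `CCCCCCCCCCCCS(=O)(=O)c1ccc(O)c(C(=O)Nc2ccc(C(F)(F)F)cc2)c1` gives 6.2 in this assay, the lower of the two numbers; compound 2 `CCCCCCCCCCCCS(=O)(=O)c1ccc(O)c(C(=O)Nc2ccc(Br)cc2)c1` gives 6.49 in this assay. For the measured compounds named here, the one step between them, a number 0.29 log units higher from compound 1 to compound 2 (within the scatter), concerns only the anilide substituent and is within the scatter.

Compound 3 `CCCCCCS(=O)(=O)c1ccc(O)c(C(=O)Nc2ccc(C(F)(F)F)cc2)c1` differs from compound 1 at the other end of the molecule: hydrogen in place of hexyl on a saturated chain carbon, six bonds along the chain from a sulfonyl sulfur. Going by the values given here, no measured step touches the length of this chain, so the pair from compound 1 to compound 2 gives no guide to the size of the present change. On general grounds, losing a hexyl fragment from a saturated chain is expected to lower the number in this assay far beyond the scatter. For compound 3 the estimated value in this assay is 3.8, in the range 3 to 4.6, which is expected to mean a step of a number 2.40 log units lower from compound 1 to compound 3 (beyond the scatter).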

Compound 3, distribution coefficient: 4.18
Estimate against measurement, compound 3: 0.38 log units below; low and high end bracket the measured number.
By their numbers in this assay, from the lowest: compound 3; then compounds 1 and 2 (each within the scatter of the next).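

In this assay, hydrogen in place of hexyl on a saturated chain carbon, six bonds along the chain from a sulfonyl sulfur, gives a number 2.02 log units lower from compound 1 to compound 3 (beyond the scatter). This is the first step in the series that lies beyond the scatter, whereas the only anilide change shown, a number 0.29 log units higher from compound 1 to compound 2 (within the scatter), stays within it, so among these compounds only the change to the sulfonyl chain separates the numbers. No available data bear on why the chain change gives a step of this size.

From the compounds shown here alone, with a single shortened chain, it remains open whether the number falls evenly with chain length, which a propyl or a nonyl chain on the sulfonyl would test. Also open, going by these compounds, are whether the step carries over to the bromo anilide and where a chain bearing an amine or a carboxylic acid would fall.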